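A Second Methoxy Group on an Aromatic Ring

This account rests on a few compounds, and the source may have more. Where it says the series, first, only, none or still open, it means among the compounds named here.

Compound 1 `COc1ccc(-c2cc(/C=C/C(=O)c3ccc(N)cc3)[nH]n2)cc1`: 2250 nM
Compound 2 `COc1cc(-c2cc(/C=C/C(=O)c3ccc(Cl)c(Cl)c3)[nH]n2)cc(OC)c1OC`: 8700 nM
Compound 3 `COc1ccc(C(=O)/C=C/c2cc(-c3cc(OC)c(OC)c(OC)c3)n[nH]2)cc1OC`: 1230 nM

All three were tested in a functional assay on SNB-75 cells (Homo sapiens) for inhibition, read by sulforhodamine B assay, with a stated time of 48 h; a lower number here means a stronger inhibitor of growth, a higher number a weaker inhibitor of growth. Compound 1 stands second highest of the three numbers; its value and that of compound 3 lie within the scatter of each other, whereas the gap to compound 2 lies beyond it. Compound 4 `COc1ccc(-c2cc(/C=C/C(=O)c3ccc(N)cc3)[nH]n2)cc1OC` differs from compound 1 by methoxy in place of hydrogen on an aromatic carbon. Among the compounds with values here, no measured step touches this part of the molecule. Within the data shown here, the only one-place step, a 7.1-fold lower number from compound 2 to compound 3 (0.85 log units; beyond the scatter), exchanges the group on the carbonyl side instead, so it bears on the present change only loosely. No movement beyond the scatter is therefore expected, and the expected step is a 1.3-fold lower number from compound 1 to compound 4 (0.10 log units; within the scatter). Compound 4 is estimated at 1800 nM, with a range from 700 nM to 4500 nM.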

Compound 4, concentration for 50% growth inhibition: 2740 nM
Beside the measured number, compound 4's estimate is 1.5-fold (0.18 log units) below it; the range from low to high includes it.
By their numbers in this assay, from the lowest: compounds 3, 1 and 4 (each within the scatter of the next, the first and the last beyond it); then compound 2.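

Replacing hydrogen with methoxy on this aromatic carbon, ortho to a methoxy group, gives a 1.2-fold higher number from compound 1 to compound 4 (0.09 log units; within the scatter) in this assay. Within the data shown here, this is the first direct reading at this position, and it shows that the added methoxy leaves growth inhibition indistinguishable from that of compound 1. No measurement on hand bears on why this result arises.

As far as these compounds go, whether a hydroxyl, an amine or a longer ethoxy chain would be accommodated equally well on this carbon remains open. So does whether methoxy here would behave the same way with a different group on the carbonyl side.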